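The source may report more compounds than this note shows. Statements on the series, on what has been measured and on what is new or still open speak of the compounds shown alone.

Measured so far:
compound 1 `O=C(N/N=C/c1c(-c2cc3ccccc3oc2=O)[nH]c2ccccc12)c1ccc(Cl)cc1`, > 200000 nM
compound 2 `O=C(N/N=C/c1c(-c2cc3ccccc3oc2=O)[nH]c2ccccc12)c1ccccc1F`, > 200000 nM

In a toxicity assay on Vero cells (Chlorocebus sabaeus) for inhibition, read by MTT assay, with a stated time of 48 h (on this read-out higher numbers stand for weaker inhibition and lower numbers for stronger inhibition), compound 1 gives > 200000 nM, which is a limit of the assay and not a number. In this assay compound 2 gives > 200000 nM, likewise a limit. Compound 2 therefore stands at the ceiling of what this assay reports, and the step that the two limits leave unreadable from compound 1 to compound 2 cannot be sized. Compound 3 `O=C(N/N=C/c1c(-c2cc3ccccc3oc2=O)[nH]c2ccccc12)c1cccc(Br)c1` differs from compound 2 by 3-bromophenyl in place of 2-fluorophenyl on a carbonyl carbon. Going by the values given here, the only measured step at this place is a step that the two limits leave unreadable from compound 1 to compound 2; both values sit at the limit of > 200000 nM in this assay, at which 2 of the 2 values shown sit, so the exchange of one halogenated phenyl for another has so far not produced a readable number in this assay. Compound 3 is expected to remain at the limit, the expected step being a step that the limit leaves unreadable from compound 2 to compound 3. The estimate for compound 3 in this assay is 250000 nM, ranging from 150000 nM to 450000 nM.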

Compound 3, half-maximal inhibitory concentration: > 200000 nM
Compound 3 ended at the assay's limit; the forecaster's own chance of this, stated with the estimate: 85%; the middle value is on the limit's open side.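

In this assay compound 3 gives > 200000 nM, a limit and not a number. No step among compound 1, compound 2 and compound 3 can be read: the limit of > 200000 nM in this assay, at which 3 of the 3 values shown sit.

The compounds shown leave open whether exchanging the halogenated phenyl on the carbonyl carbon changes this read-out at all.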